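Swapping the acidic ring of compound 2 for a cyclic urea

The source may hold more compounds than are shown below. What is called first, only, known or untested is meant among the compounds shown, and "the series" means these compounds.

Measured so far:
compound 1, `CC(C)C(Cc1noc(=O)[nH]1)c1ccc(-c2ccc3cccc(F)c3c2)[nH]c1=O`, 34 nM
compound 2, `CC(C)C(c1noc(=O)[nH]1)c1ccc(-c2ccc3cccc(F)c3c2)[nH]c1=O`, 15 nM

Both compounds were tested in an assay on CHO cells for displacement of a labelled ligand from prostaglandin E2 receptor EP3 subtype (Homo sapiens), read by radioligand binding; on this read-out higher numbers stand for weaker inhibition and lower numbers for stronger inhibition. Compound 1 gives 34 nM and compound 2 gives 15 nM; the shortening of the chain that links the five-membered ring to the core produced a 2.3-fold lower number from compound 1 to compound 2 (0.36 log units; beyond the scatter). Among the two numbers, compound 2 holds the lower one.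

Compound 3, `CC(C)C(c1ccc(-c2ccc3cccc(F)c3c2)[nH]c1=O)N1CCNC1=O`, has not been measured. Its change from compound 2 is a group of 6 heavy atoms (3 carbon, 2 nitrogen, 1 oxygen; one five-membered non-aromatic ring with 2 hetero atoms) in place of a group of 6 heavy atoms (2 carbon, 2 nitrogen, 2 oxygen; one five-membered aromatic ring with 3 hetero atoms), on a saturated chain carbon bound to an aromatic carbon and a saturated chain carbon. For the measured compounds named here, the only measured step concerns the length of the chain between the core and the five-membered ring, not the identity of the ring itself, so no step bears directly on this change. With no guidance from the data on replacing one ring by another, a somewhat weaker outcome with a wide uncertainty is the reasonable expectation. The step from compound 2 to compound 3 in this assay is therefore expected to be an 8.0-fold higher number from compound 2 to compound 3 (0.90 log units; beyond the scatter). Compound 3 is estimated to give 120 nM, within a range from 25 nM to 600 nM.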

Compound 3, inhibition constant in the prostaglandin E2 receptor EP3 subtype assay: 9.1 nM
Compound 3: middle estimate off by 13-fold (1.12 log units), on the high side, outside the stated range (below it).
By their numbers in the prostaglandin E2 receptor EP3 subtype assay, from the lowest: compounds 3 and 2 (each within the scatter of the next); then compound 1.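

In the prostaglandin E2 receptor EP3 subtype assay compound 2 gives 15 nM and compound 3 gives 9.1 nM; replacing the aromatic five-membered ring on the saturated chain carbon with 2-oxoimidazolidin-1-yl gives a 1.6-fold lower number from compound 2 to compound 3 (0.22 log units; within the scatter), so this position accepts a non-aromatic ring with no change beyond the scatter, which the chain-length step between compound 1 and compound 2 could not show. The new ring also carries the gain seen earlier over compound 1, with a 3.7-fold lower number from compound 1 to compound 3 (0.57 log units; beyond the scatter), and this step lies beyond the scatter. In a physicochemical assay for solubility, measured as kinetic solubility, at pH 2 (on this read-out higher numbers stand for higher solubility and lower numbers for lower solubility), compound 2 gives 23200 nM and compound 3 gives 31600 nM; the same replacement gives a 1.4-fold higher number from compound 2 to compound 3 (0.13 log units; within the scatter), so neither read-out separates compound 2 from compound 3.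

The data shown offer no explanation for why these two different rings read alike. From the compounds shown here alone, it remains open how far this tolerance extends, for example to a six-membered cyclic urea, an open-chain urea, a carboxylic acid on the same carbon, or a methyl group on the ring nitrogen of 2-oxoimidazolidin-1-yl that still bears a hydrogen.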